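Homologating the amine substituent of compound 1 toward a benzyl chain

The compounds below may be only part of what the source reports. "The series", "measured", "known", "first", "only" and "open" are said of these compounds alone.

Compound 1 `CC(C)CCN(C)Cc1ccc(C2=CCCN(C)C2)cc1` gives > 50000 nM in an ADME assay on HL-60 cells (Homo sapiens) for cytotoxicity, read by MTT assay, with a stated time of 24 h (a lower number here means a stronger inhibitor, a higher number a weaker inhibitor), a limit of the assay.
Compound 2 `CN1CCC=C(c2ccc(CN(C)Cc3ccccc3)cc2)C1` gives > 50000 nM in this assay, likewise a limit.
Compound 3 `CN1CCC=C(c2ccc(CN(C)Cc3ccc([N+](=O)[O-])cc3)cc2)C1` gives 28000 nM in this assay.

Compound 1 thus stands at the limit of this assay, and only a limit is known for it; compound 2 sits at the same limit (the limit of > 50000 nM in this assay, at which 2 of the 3 values shown sit), so two of the three values shown are limits rather than numbers. Compound 4 `CN1CCC=C(c2ccc(CN(C)CCCc3ccccc3)cc2)C1` differs from compound 1 by benzyl in place of isopropyl on a saturated chain carbon, two bonds along the chain from an amine nitrogen. The closest measured step is a step that the two limits leave unreadable from compound 1 to compound 2, which the two limits leave unreadable. Among the measured compounds shown here, the only readable step, an at least 1.7-fold lower number from compound 2 to compound 3 (0.25 log units; that floor lies within the scatter), concerns a different position and a floor that lies within the scatter. For the measured compounds named here, no measured step therefore speaks for a change beyond the scatter, and compound 4 is expected to sit at or near the limit, with a number no higher from compound 1 to compound 4 (the limit leaves the size open) as the estimated step. Compound 4 is estimated at 50000 nM, between 20000 nM and 200000 nM.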

Compound 4, half-maximal inhibitory concentration: > 50000 nM
Compound 4 ended at the assay's limit (the forecaster's own chance of this, stated with the estimate: 70%); the middle value lies on the limit itself.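

The steps from compound 1 and compound 2 to compound 4 cannot be read, since all three compounds stand at a limit in this assay: the limit of > 50000 nM in this assay, at which 3 of the 4 values shown sit.

The compounds shown leave open how far compound 1, compound 2 and compound 4 lie from one another in this assay.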